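A few compounds are considered here, and "the series" means these few. Any claim that something is new, unique, unknown or untested is made for them only; others in the source may bear on it.

Three compounds have been measured in a functional assay on HepG2 cells (Homo sapiens) for cytotoxicity, read by MTT assay, with a stated time of 48 h; on this read-out lower numbers stand for stronger inhibition and higher numbers for weaker inhibition:

compound 1, `CC1=NN(C(=O)c2ccc(C)cc2)C(c2cc(Br)ccc2O)C1`, gives 23200 nM
compound 2, `CC(=O)Oc1ccccc1C1CC(C)=NN1C(=O)CN1CCC(O)CC1`, gives 12300 nM
compound 3, `O=C(c1ccccc1)N1N=C(c2cc3ccccc3oc2=O)CC1c1ccccc1`, gives 36600 nM

Compound 3 stands at the highest of these three numbers. Its nearest neighbour is compound 1, whose number lies within the scatter of repeated measurements, so nothing can be said about an order between these two. Compound 2 is further away, with a number that is lower by more than the scatter.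

Compound 4, `O=C(CN1CCC(O)CC1)N1N=C(c2cc3ccccc3oc2=O)CC1c1ccccc1`, shares the core of compound 3 and differs from it in one place: (4-hydroxypiperidin-1-yl)methyl in place of phenyl on a carbonyl carbon. Among the compounds with values here, no measured pair shows this exact change on a shared core, so the size of the step can only be expected, not read off. Within the data shown here, compound 2 carries the same entering group on a different core and gives 12300 nM, the lowest number so far; this is a weak hint at best, since compound 2 also differs from compound 3 elsewhere. A small step toward lower numbers in this assay is expected, possibly within the scatter. Compound 4 is estimated at 25000 nM, in the range 8000 nM to 70000 nM, which means an expected step of a 1.5-fold lower number from compound 3 to compound 4 (0.17 log units; within the scatter).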

Compound 4, half-maximal inhibitory concentration: "not active" (no number reported)
No number was reported for compound 4; the estimate stays without a comparison.
By their numbers in this assay, from the lowest: compounds 2, 1 and 3 (each within the scatter of the next, the first and the last beyond it).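

Within the data shown here, compound 4 is reported in this assay as not active, without a number, so no step from compound 3 to compound 4 can be read. From the compounds shown here alone, how far (4-hydroxypiperidin-1-yl)methyl in place of phenyl shifts the number on this shared core stays open. No measurement shown offers an explanation for this result.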